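This account rests on a few compounds, and the source may have more. Where it says the series, first, only, none or still open, it means among the compounds named here.

Working notes on a short series tested in a functional assay on NCI-H1299 cells (Homo sapiens) for inhibition, with a stated time of 48 h, at 37 degrees C; on this read-out higher numbers stand for weaker inhibition of growth and lower numbers for stronger inhibition of growth. Compound 1 `Clc1ccc(-c2noc(-c3occc3Br)n2)cc1` and compound 2 `Clc1ccc(-c2noc(-c3occc3Cl)n2)cc1` share one core and differ by chloro in place of bromo on an aromatic carbon. Compound 3 `Clc1ccc(-c2noc(-c3occc3Br)n2)nc1` is built on another core; the difference between the two cores is not broken down here. Compound 4 `Clc1ccc(-c2noc(-c3occc3Cl)n2)nc1` has not yet been measured.

In this assay compound 1 gives a limit of the assay, > 10000 nM. In this assay compound 2 likewise gives a limit, > 10000 nM. In this assay compound 3 also gives a limit, > 10000 nM. The step that the two limits leave unreadable from compound 1 to compound 2 is therefore unreadable, because of the limit of > 10000 nM in this assay, at which 3 of the 3 values shown sit.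

The change from compound 3 to compound 4 is the same change: chloro in place of bromo on an aromatic carbon. For the measured compounds named here, its single measured instance left no readable step, and no compound has a numerical value. The expected step is a step that the limit leaves unreadable from compound 3 to compound 4, resting on the unreadable step that the two limits leave unreadable from compound 1 to compound 2. Compound 4 is estimated at 20000 nM, with an expected range from 8000 nM to 60000 nM, and the reading is expected most likely to be a limit once more.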

Compound 4, concentration for 50% growth inhibition: > 10000 nM
Compound 4: a limit, no number; the forecaster's own chance of this, stated with the estimate: 85%; the middle value is on the limit's open side.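

No new step can be read from compound 3 to compound 4, because both values are limits of the assay and not numbers: the limit of > 10000 nM in this assay, at which 4 of the 4 values shown sit.

The compounds shown leave open how bromo and chloro compare on either core, and whether either core gives measurable inhibition of growth, as no compound here has a numerical value.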